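A few compounds are considered here, and "the series" means these few. Any claim that something is new, unique, unknown or untested is made for them only; others in the source may bear on it.

Measured compounds in an ADME assay on the whole organism (Rattus norvegicus) for pharmacokinetics; on this read-out higher numbers stand for fast clearance and lower numbers for slow clearance:

- Compound 1 `COc1ccc(C(=O)C2=C(O)C(=O)N(c3ccc(-c4ccon4)cc3)C2C2CCCCC2)cn1`, in this assay compound 1 gives 4.6 mL/min/kg
- Compound 2 `CCC(CC)C1C(C(=O)c2ccc(OC)cc2)=C(O)C(=O)N1c1ccc(-c2ccon2)cc1`, in this assay compound 2 gives 5.1 mL/min/kg

Compound 3 `Cc1nc(-c2ccc(N3C(=O)C(O)=C(C(=O)C(C)(C)C)C3c3ccccc3OCCO)cc2)no1` belongs to the same series, but for compound 3 this assay gives "not determined" (no result reported), so there is no number to place it against compound 1 or compound 2. The two numbers that exist, from compound 1 and compound 2, lie close to each other and both stand at the slow end of clearance.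

Compound 4 `CC(C)(C)C(=O)C1=C(O)C(=O)N(c2ccc(-c3ccsc3)cc2)C1c1ccccc1OCCO` differs from compound 3 in one place: thiophen-3-yl in place of 5-methyl-1,2,4-oxadiazol-3-yl on an aromatic carbon. Within the data shown here, since compound 3 has no measurement, no step between measured compounds can be stated, and the change is judged only against the series as a whole. With compound 1 at 4.6 mL/min/kg and compound 2 at 5.1 mL/min/kg as the only anchors, a result of similar size is expected, with room for a moderate rise that would still be within the ordinary scatter. Compound 4 is therefore estimated at 8 mL/min/kg, within a range from 3 mL/min/kg to 25 mL/min/kg.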

Compound 4, clearance: 0.5 mL/min/kg
Compound 4: middle estimate off by 16-fold (1.20 log units), on the high side, and the stated range ends above it.
By their numbers in this assay, from the lowest: compound 4; then compounds 1 and 2 (each within the scatter of the next).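

In this assay compound 3 has no number to set against compound 4, so no step can be read between them. Going by these compounds, what swapping 5-methyl-1,2,4-oxadiazol-3-yl for thiophen-3-yl does to clearance stays open. No measurement at hand offers an explanation for the value of compound 4.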